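A few compounds are considered here, and "the series" means these few. Any claim that something is new, unique, unknown or untested is made for them only; others in the source may bear on it.

Measured in a functional assay on HT-29 cells (Homo sapiens) for inhibition; a lower number here means a stronger inhibitor, a higher number a weaker inhibitor:
Compound 1 `Oc1ccc(/C=C/c2ccc3ccccc3c2)cc1` gives 4060 nM
Compound 2 `COc1cc(/C=C\c2ccc3ccccc3c2)ccc1F` gives 450 nM
Compound 3 `FC(F)(F)Oc1cccc(/C=C\c2ccc3ccccc3c2)c1` gives 3500 nM

Compound 1 and compound 3 lie within the scatter of each other, while compound 2 has a lower number than both, beyond the scatter. Compound 1 therefore stands at the weak end of this small set.

Compound 4 `FC(F)(F)c1ccc(/C=C/c2ccc3ccccc3c2)cc1` keeps the double-bond geometry of compound 1 and changes one group: trifluoromethyl in place of hydroxy on an aromatic carbon. Within the data shown here, no measured pair differs in one place only, so the data give no direct precedent for this exchange. Compound 3 also lacks the hydroxy group, and at 3500 nM it stays within the scatter of compound 1. Compound 2 at 450 nM shares the other double-bond geometry with compound 3 and offers weaker guidance. In this assay no change beyond the scatter is expected, and the estimated step is a 1.4-fold lower number from compound 1 to compound 4 (0.13 log units; within the scatter) in size. For compound 4 the estimated value is 3000 nM with an expected range of 900 nM to 10000 nM.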

Compound 4, half-maximal inhibitory concentration: > 5000 nM
Compound 4: only a limit was reported; the forecaster's own chance of this, stated with the estimate: 15%; middle value at least 1.6-fold (0.22 log units) from the limit.
By their numbers in this assay, from the lowest: compound 2; then compounds 3 and 1 (each within the scatter of the next). At a limit, above all of these: compound 4.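

In this assay, compound 4 is reported only as a limit, > 5000 nM. Trifluoromethyl in place of hydroxy para to a large group gives the first single-place step in the series, an at least 1.2-fold higher number from compound 1 to compound 4 (0.09 log units; that floor lies within the scatter), so this exchange shows no gain in strength on the core of compound 1, while the floor of the step does not separate a real loss from the scatter. The full size of the step cannot be read, as the reading ends at a limit: the limit of > 5000 nM in this assay, at which 1 of the 4 values shown sits.

As far as these compounds go, whether a group such as an amine or a carboxylic acid on the same aromatic carbon would read differently from hydroxy remains open. From the compounds shown here alone, the role of the double-bond geometry also remains open, since compound 2 and compound 3 each differ from compound 1 in more than one place.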